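This account rests on a few compounds, and the source may have more. Where it says the series, first, only, none or still open, it means among the compounds named here.

Working notes on the series. Of the compounds shown here, two have been measured so far: compound 1 `O=C(CN1CCCCC1)Nc1ccc(-c2nc3cc(C(F)(F)F)ccc3[nH]2)cc1` and compound 2 `O=C(CCl)Nc1ccc(-c2nc3cc(C(F)(F)F)ccc3[nH]2)cc1`, which share the core and differ only at the end of the chain bound to the carbonyl carbon. In an ADME assay on MT4 cells (Homo sapiens) for cytotoxicity, read by MTT assay, with a stated time of 96 h (a lower number here means that less compound is tolerated, a higher number that more compound is tolerated), compound 1 gives 6000 nM. In this assay compound 2 gives 5000 nM. The one measured step, a 1.2-fold lower number from compound 1 to compound 2 (0.08 log units; within the scatter), lies within the scatter, so on the numbers shown compound 2 stands at the lower of the two values with compound 1 as its nearest neighbour, and no order between them is claimed.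

Compound 3 `COc1ccc(-c2nc3cc(C(F)(F)F)ccc3[nH]2)cc1` is the next candidate for this assay. It differs from compound 2 at the aromatic carbon: methoxy in place of ((chloromethyl)carbonyl)amino on an aromatic carbon. Going by the values given here, the only measured step concerns the saturated chain carbon and not the group on the aromatic carbon, so no measured step bears directly on this change; what the two measured values show is that a change at the chain end left the number within the scatter. Lacking any step at this place, a step of no more than the scatter is expected, a 1.4-fold higher number from compound 2 to compound 3 (0.15 log units; within the scatter). Compound 3 is therefore estimated at 7000 nM, with a range of 2000 nM to 25000 nM.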

Compound 3, half-maximal cytotoxic concentration: 2000 nM
Compound 3: middle estimate off by 3.5-fold (0.54 log units), on the high side; the range from low to high includes it.
By their numbers in this assay, from the lowest: compound 3; then compounds 2 and 1 (each within the scatter of the next).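

In this assay, going by these compounds alone, the group on the aromatic carbon, para to a large group, gives the first step beyond the scatter: methoxy in place of ((chloromethyl)carbonyl)amino produces a 2.5-fold lower number from compound 2 to compound 3 (0.40 log units; beyond the scatter), a modest step, whereas the change at the chain end in a 1.2-fold lower number from compound 1 to compound 2 (0.08 log units; within the scatter) stayed within the scatter. This single step removes the carbonyl, the chlorine and the only hydrogen-bond donor of the leaving group together, going from 5 heavy atoms to 2, so the compounds do not assign the lower number to any one of these parts. No measurement at hand accounts for this step.

Going by these compounds, it remains open whether a small group with a donor, such as an amine or a hydroxy on the same aromatic carbon, would stay close to compound 2 or to compound 3, and whether a simple acetamide without the chlorine would do the same. Also open, on these data alone, is how a longer chain such as ethoxy in place of methoxy would read, and whether a replacement for the trifluoromethyl, held constant in all three compounds, would move the number.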